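This account rests on a few compounds, and the source may have more. Where it says the series, first, only, none or still open, it means among the compounds named here.

Measured compounds:
Compound 1 `COc1ccc(/C=C2\Cc3cc(OC)c(OC)c(OC)c3C2=O)cc1O` – in a functional assay on PC-3 cells (Homo sapiens) for antiproliferative activity, read by MTT assay, with a stated time of 48 h (a lower number here means a stronger inhibitor of growth, a higher number a weaker inhibitor of growth), compound 1 gives > 10000 nM.
Compound 2 `COc1ccc(/C=C2\Cc3cc(OC)c(OC)c(OC)c3C2=O)cc1` – in this assay compound 2 gives > 10000 nM.

The value of compound 1 is a limit of the assay, not a number. The value of compound 2 is likewise a limit, not a number, so compound 2 stands at the edge of what the assay can read, with the same true for (the limit of > 10000 nM in this assay, at which 2 of the 2 values shown sit). Because of this, the step that the two limits leave unreadable from compound 1 to compound 2 cannot be read in size or direction.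

Compound 3 `COc1ccc(/C=C2\Cc3cc(OC)c(OC)c(OC)c3C2=O)cc1N` is next, differing from compound 2 by amino in place of hydrogen on an aromatic carbon. No measured step bears on this change in a readable way, since the one step shown is unreadable. The expectation is therefore that compound 3 will again sit at the limit, with the step that the limit leaves unreadable from compound 2 to compound 3 expected to be small. Compound 3 is estimated at 15000 nM, in a range from 3000 nM to 60000 nM.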

Compound 3, concentration for 50% growth inhibition: > 10000 nM
Compound 3 gave a limit, no number; the forecaster's own chance of this, stated with the estimate: 70%; the middle value is on the limit's open side.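

Among the compounds shown here, compound 3 also gives only a limit, not a number, in this assay, so no step among compound 1, compound 2 and compound 3 can be read: the limit of > 10000 nM in this assay, at which 3 of the 3 values shown sit.

The compounds shown leave open whether hydroxy, hydrogen or amino at this place changes growth inhibition at all, and how strongly any of the three acts.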